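A few compounds are considered here, and "the series" means these few. Any claim that something is new, unique, unknown or untested is made for them only; others in the source may bear on it.

Measured so far in a physicochemical assay for permeability, using PAMPA; a higher number here means that the compound crosses the layer faster, a lower number that the compound crosses the layer more slowly:
- compound 1 `C[C@@H](Oc1cc2oc(=O)n(CCC(=O)O)c2cc1Cl)c1ccc(F)cn1` gives 31 nm/s
- compound 2 `C[C@@H](Oc1cc2oc(=O)n(CCC(=O)O)c2cc1Cl)c1ccc(Cl)cn1` gives 60 nm/s

Compound 2 gives 60 nm/s and compound 1 gives 31 nm/s in a set of just two numbers. These lie within the usual scatter of each other, so they cannot be ranked.

Compound 3 `Cc1ccnc([C@@H](C)Oc2cc3oc(=O)n(CCC(=O)O)c3cc2Cl)c1` has 4-methylpyridin-2-yl in place of 5-chloropyridin-2-yl, and the exchange comes down to 4-methylpyridin-2-yl in place of 5-chloropyridin-2-yl on a saturated chain carbon bound to an oxygen on an aromatic ring and a saturated chain carbon with the rest of the molecule unchanged.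

Within the data shown here, only one measured step bears on this change: a 1.9-fold higher number from compound 1 to compound 2 (0.29 log units; within the scatter) for chloro in place of fluoro on an aromatic carbon. Among the measured compounds shown here, no measured compound carries 4-methylpyridin-2-yl, so that step is only a loose guide. Going by it, no step beyond the scatter is expected in this assay here, and the estimated step is a 1.3-fold lower number from compound 2 to compound 3 (0.12 log units; within the scatter) with no firm direction behind it. The estimate for compound 3 is 45 nm/s with an expected range from 18 nm/s to 110 nm/s in this measurement.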

Compound 3, apparent permeability: < 3 nm/s
Compound 3: only a limit was reported; the forecaster's own chance of this, stated with the estimate: 5%; middle value at least 15-fold (1.17 log units) away from the limit.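

In this assay, the group on the saturated chain carbon bound to an oxygen on an aromatic ring proves able to shift the read-out far beyond the scatter: placing 4-methylpyridin-2-yl there gives an at least 20-fold lower number from compound 2 to compound 3 (1.30 log units; beyond the scatter) and an at least 10-fold lower number from compound 1 to compound 3 (1.01 log units; beyond the scatter). Among these compounds, the earlier compounds could not show this, as their only step, chloro in place of fluoro, stayed within the scatter at a 1.9-fold higher number from compound 1 to compound 2 (0.29 log units; within the scatter), and the large steps now appear even though the groups that leave and enter have the same counts of heavy atoms, hydrogen-bond donors and hydrogen-bond acceptors. The true size of both new steps remains unknown, as compound 3 sits at a limit of the assay rather than at a number: the limit of < 3 nm/s in this assay, at which 1 of the 3 values shown sits.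

The names 5-chloropyridin-2-yl and 4-methylpyridin-2-yl differ both in the group carried and in its number on the ring, and the compounds shown leave open which of the two goes with the drop. They also leave open how a pyridine ring carrying an amine or a methoxy group would read in this assay.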